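Fluoro removal on the cinnamoyl arm of thiadiazole amides

The source may hold more compounds than are shown below. What is called first, only, known or untested is meant among the compounds shown, and "the series" means these compounds.

Compound 1 `COc1ccc(-c2nnc(NC(=O)/C=C/c3ccc(F)cc3)s2)cc1` gives 0.75 ug/mL in a functional assay on A549 cells (Homo sapiens) for antiproliferative activity, read by MTT assay, with a stated time of 48 h; on this read-out higher numbers stand for weaker inhibition and lower numbers for stronger inhibition. Compound 2 `COc1ccc(-c2nnc(NC(=O)/C=C/c3ccccc3)s2)cc1` carries the change hydrogen in place of fluoro on an aromatic carbon and gives 0.68 ug/mL in this assay; the step of a 1.1-fold lower number from compound 1 to compound 2 (0.04 log units; within the scatter) is too small to separate the two.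

Compound 3 `O=C(/C=C/c1ccc(F)cc1)Nc1nnc(-c2ccc(Cl)cc2)s1` differs from compound 1 in its core by chloro in place of methoxy on an aromatic carbon. In this assay compound 3 gives 2.06 ug/mL; the step of a 2.7-fold higher number from compound 1 to compound 3 (0.44 log units; beyond the scatter) places compound 3 as the highest of the three measured numbers.

Compound 4 `O=C(/C=C/c1ccccc1)Nc1nnc(-c2ccc(Cl)cc2)s1` is not yet measured. It stands to compound 3 as compound 2 stands to compound 1: the change hydrogen in place of fluoro on an aromatic carbon is the same change as that from compound 1 to compound 2, with the same surroundings of the place, only now on the core of compound 3 rather than that of compound 1. The step from compound 3 to compound 4 is expected to be a 1.1-fold lower number from compound 3 to compound 4 (0.04 log units; within the scatter) in this assay, a small move, because the corresponding step of a 1.1-fold lower number from compound 1 to compound 2 (0.04 log units; within the scatter) lay within the scatter. Compound 4 is accordingly estimated at 1.9 ug/mL in this assay, with a likely range from 1 ug/mL to 3.8 ug/mL.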

Compound 4, half-maximal inhibitory concentration: 2.02 ug/mL
For compound 4 the middle estimate is 1.1-fold (0.03 log units) below the measured one, within the range that was stated.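

In this assay, 4-fluorophenyl to phenyl on the chloro-bearing core gives a 1.0-fold lower number from compound 3 to compound 4 (0.01 log units; within the scatter), and this agrees with the same change on the core of compound 1: the same change on two cores in this assay, a 1.1-fold lower number (0.04 log units; within the scatter) from compound 1 to compound 2 and a 1.0-fold lower number (0.01 log units; within the scatter) from compound 3 to compound 4, 1.1-fold (0.03 log units) apart, within the scatter of two such steps. The change of methoxy to chloro also carries over between the fluoro and hydrogen pairs, with a 3.0-fold higher number from compound 2 to compound 4 (0.47 log units; beyond the scatter), and again the two steps agree: the same change on two cores in this assay, a 2.7-fold higher number (0.44 log units; beyond the scatter) from compound 1 to compound 3 and a 3.0-fold higher number (0.47 log units; beyond the scatter) from compound 2 to compound 4, 1.1-fold (0.03 log units) apart, within the scatter of two such steps. Within these four compounds, each change reads the same in both settings, but this rests on two pairs per change in one assay, so it does not show that either change would carry over to any other core or cell line, and it gives no reason for the agreement.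

Open, going by these compounds, is whether another group in the place of the fluoro, such as an amine or a carboxylic acid, would move the number, given that only fluoro and hydrogen appear there. Equally open, on these data alone, is whether a nitrile or a longer chain in the place of the methoxy would follow the chloro compounds or the methoxy compounds.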